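Naphthyloxyacetyl hydrazones: cytotoxicity on HEL cells, compound 3

The source may report more compounds than this note shows. Statements on the series, on what has been measured and on what is new or still open speak of the compounds shown alone.

compound 1, `C/C(=N\NC(=O)COc1cccc2ccccc12)c1ccc(O)cc1O`: 74.8 ug/mL
compound 2, `C/C(=N\NC(=O)COc1cccc2ccccc12)c1ccc(O)cc1`: 11.1 ug/mL

In an ADME assay on HEL cells (Homo sapiens) for cytotoxicity (a lower number here means that less compound is tolerated, a higher number that more compound is tolerated), compound 2 gives 11.1 ug/mL, the lowest of the two numbers, with compound 1 standing above it. Compound 3, `C/C(=N\NC(=O)COc1cccc2ccccc12)c1ccc([N+](=O)[O-])cc1`, differs from compound 2 by nitro in place of hydroxy on an aromatic carbon, the nitro sitting para to a large group on the six-membered aromatic ring of carbon only. Among the compounds with values here, only a 6.7-fold lower number from compound 1 to compound 2 (0.83 log units; beyond the scatter) touches the hydroxy that leaves; no measured step covers nitro entering. In this assay a step within the scatter is therefore expected, a 1.3-fold higher number from compound 2 to compound 3 (0.10 log units; within the scatter). For compound 3 the estimate is 14 ug/mL, range 5 ug/mL to 40 ug/mL.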

Compound 3, half-maximal cytotoxic concentration: > 100 ug/mL
Compound 3 was reported as a limit (the forecaster's own chance of this, stated with the estimate: 10%); middle value at least 7.1-fold (0.85 log units) from the limit.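

In this assay, nitro on this aromatic carbon, para to a large group, gives an at least 9.0-fold higher number from compound 2 to compound 3 (0.95 log units; beyond the scatter), so this position tolerates a change that lifts the number well clear of the 4-hydroxyphenyl compound. Compound 3 is reported only as a limit: the limit of > 100 ug/mL in this assay, at which 1 of the 3 values shown sits. Set against the 2,4-dihydroxyphenyl compound, the change reads an at least 1.3-fold higher number from compound 1 to compound 3 (0.12 log units; that floor lies within the scatter), so this pair has no settled order.

As far as these compounds go, whether an amine, a carboxylic acid or a nitrile at this place would behave like nitro remains open. From the compounds shown here alone, the true value of compound 3 also remains open.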